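Cyclohexyl to pyridin-2-yl on the piperazine nitrogen

The compounds below may be only part of what the source reports. "The series", "measured", "known", "first", "only" and "open" are said of these compounds alone.

Three analogues sharing one core have been measured in an assay on membranes from liver for displacement of a labelled ligand from Sigma intracellular receptor 2 (Rattus norvegicus), read by scintillation counting, with a stated time of 120 min; on this read-out lower numbers stand for stronger inhibition and higher numbers for weaker inhibition. Compound 1 `CCCCN1CCN(CCC(=O)Nc2nc3c(C)cccc3s2)CC1` gives 1200 nM. Compound 2 `Cc1cccc2sc(NC(=O)CCN3CCN(CCCN(C)C)CC3)nc12` reaches only a limit of the assay, > 1000 nM, as noted in the limit of > 1000 nM in this assay, at which 1 of the 3 values shown sits. Compound 3 `Cc1cccc2sc(NC(=O)CCN3CCN(C4CCCCC4)CC3)nc12` gives 233 nM, the lowest number among the two numeric values, with a 5.2-fold lower number from compound 1 to compound 3 (0.71 log units; beyond the scatter) and an at least 4.2-fold lower number from compound 2 to compound 3 (0.63 log units; beyond the scatter) both lying beyond the scatter. Compound 4 `Cc1cccc2sc(NC(=O)CCN3CCN(c4ccccn4)CC3)nc12` carries the change (pyridin-2-yl in place of cyclohexyl on an amine nitrogen in a ring). Among the measured compounds shown here, no measured step exchanges one ring for another on this nitrogen: the two steps toward compound 3 replaced open chains with the cyclohexyl ring, and neither speaks to an aromatic ring bearing a hydrogen-bond acceptor. Compound 3 therefore anchors the expectation, while the weaker numbers of compound 1 and compound 2 mark how far a different substituent can move the value. Compound 4 is estimated at 450 nM, between 120 nM and 1800 nM, which would be a step of a 1.9-fold higher number from compound 3 to compound 4 (0.29 log units; within the scatter) in this assay.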

Compound 4, inhibition constant: > 1000 nM
Compound 4 was reported as a limit; the forecaster's own chance of this, stated with the estimate: 20%; middle value at least 2.2-fold (0.34 log units) away from the limit.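

Having a ring on this nitrogen is not enough in itself to hold the lower number: cyclohexyl and pyridin-2-yl have the same count of heavy atoms, yet this assay records an at least 4.2-fold higher number from compound 3 to compound 4 (0.63 log units; beyond the scatter). Among the compounds shown here, the earlier steps had only set the cyclohexyl ring against open chains, so this is the first sign that the kind of ring matters here. Compound 4 is reported only as a limit, and it joins compound 2 there: the limit of > 1000 nM in this assay, at which 2 of the 4 values shown sit. The steps from compound 1 and compound 2 to compound 4 therefore cannot be read.

From the compounds shown here alone, it stays open whether the loss goes with the aromatic ring or with its ring nitrogen, which a phenyl group on the same nitrogen would separate. Going by these compounds, it also stays open whether a piperidin-4-yl or cyclopentyl ring would match cyclohexyl.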